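A few compounds are considered here, and "the series" means these few. Any claim that something is new, unique, unknown or untested is made for them only; others in the source may bear on it.

Measured compounds: compound 1 `CCCCCCNC(=O)CC1CCc2cc(OC)c(OC)cc21`; compound 2 `COc1cc2c(cc1OC)C(CC(=O)NC1CCCCC1)CC2`.

In a functional assay on the whole organism (strain Wistar) for inhibition, with Rattus norvegicus as the target, read by paw edema, with stated times of 60 min and 24 h, at a dose of 100 mg/kg by the oral route (on this read-out higher numbers stand for more inhibition at the one dose given (going by the name of the read-out) and lower numbers for less inhibition), compound 1 gives 45.5%, and in the same test compound 2 gives 53.3%. Compound 2 thus carries the larger of the two numbers, yet the step of a number 7.8 percentage points higher from compound 1 to compound 2 (within the scatter) lies within the scatter. Compound 3 `COc1cc2c(cc1OC)C(CC(=O)NCCO)CC2` differs from compound 2 by 2-hydroxyethyl in place of cyclohexyl on an amide-type nitrogen. Among the measured compounds shown here, the only measured step, a number 7.8 percentage points higher from compound 1 to compound 2 (within the scatter), concerns another exchange on the same nitrogen and was small, so nothing here supports a step beyond the scatter. The step to compound 3 is therefore expected to be a number 7.3 percentage points lower from compound 2 to compound 3 (within the scatter). Compound 3 is estimated at 46%, between 26% and 64%.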

Compound 3, a percentage reported as inhibition, in the whole organism at one dose (the size of the read-out at that dose, not a potency): 13.3%
For compound 3 the middle estimate is 32.7 percentage points above the measured one; the whole stated range lies above it.
By their numbers in this assay, from the lowest: compound 3; then compounds 1 and 2 (each within the scatter of the next).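

In this assay, the exchange on the amide-type nitrogen proves far from neutral: the change to 2-hydroxyethyl gives a number 40 percentage points lower from compound 2 to compound 3 (beyond the scatter), and the same group measured against the hexyl amide gives a number 32.2 percentage points lower from compound 1 to compound 3 (beyond the scatter). The position therefore does respond to its substituent, which the two carbon-only groups, hexyl and cyclohexyl, within the scatter of each other, did not reveal. Nothing available accounts for the drop. The compounds shown leave open whether it goes with the hydroxy group or with the shorter chain; a plain ethyl group or a 4-hydroxybutyl chain on this nitrogen would separate the two.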